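The source may hold more compounds than are shown below. What is called first, only, known or untested is meant among the compounds shown, and "the series" means these compounds.

Among the compounds with values here, in an ADME assay on S9 fraction from liver (Rattus norvegicus, strain Wistar) for metabolic stability, tested at 0.1 uM (a higher number here means faster removal of the compound, a lower number slower removal), compound 1 `CCN(CC)c1cc(OCc2cc(F)c(Oc3ccc(Cl)c(C(F)(F)F)c3)c(F)c2)nc(=O)n1C` gives 41.9 mL/min/kg, the lower of the two numbers measured so far, while compound 2 `CN(c1cc(OCc2cc(F)c(Oc3ccc(Cl)c(C(F)(F)F)c3)c(F)c2)nc(=O)n1C)C1CC1` gives 123 mL/min/kg. Compound 3 `Cn1c(N2CCCCC2)cc(OCc2cc(F)c(Oc3ccc(Cl)c(C(F)(F)F)c3)c(F)c2)nc1=O` keeps the core of compound 1 but swaps its amine group: piperidin-1-yl in place of diethylamino on an aromatic carbon. Within the data shown here, the one measured step at this place is a 2.9-fold higher number from compound 1 to compound 2 (0.47 log units; beyond the scatter), with cyclopropyl(methyl)amino in place of diethylamino. With only that modest rise to go on, a smaller rise in this assay is expected here. The expected step is a 1.5-fold higher number from compound 1 to compound 3 (0.17 log units; within the scatter). For compound 3 the estimated clearance is 62 mL/min/kg, with a range of 30 mL/min/kg to 125 mL/min/kg.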

Compound 3, clearance: 21.8 mL/min/kg
Beside the measured number, compound 3's estimate is 2.8-fold (0.45 log units) above it; the measured number lies below the stated range.
By their numbers in this assay, from the lowest: compounds 3 and 1 (each within the scatter of the next); then compound 2.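

In this assay, the ring of piperidin-1-yl in place of the open diethylamino group leaves the number within the scatter (a 1.9-fold lower number from compound 1 to compound 3 (0.28 log units; within the scatter)), so compound 3 cannot be told apart from compound 1. The other comparison (a 5.6-fold lower number from compound 2 to compound 3 (0.75 log units; beyond the scatter)) goes beyond the scatter, so among these compounds, the choice of amine at this place can matter, and a ring alone does not bring a high number. Nothing available explains the difference between these amines.

As far as these compounds go, whether a smaller pyrrolidin-1-yl ring or a morpholin-4-yl ring, which carries an oxygen, would match compound 3 remains open.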